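The compounds below may be only part of what the source reports. "The series", "measured", "known", "first", "only" and "open" are said of these compounds alone.

Compound 3 `O=C(NO)c1ccc(NCc2nc(-c3ccc(Cl)cc3)nn2-c2ccccc2)cc1` is one of three hydroxamic acids that share a core and differ only in the aromatic group attached to it. In an assay on Sf9 cells for inhibition of protein deacetylase HDAC6 (Homo sapiens), read by fluorescence, with a stated time of 40 min, tested at 100 nM (a lower number here means less inhibition, a higher number more inhibition at the concentration tested (going by the name of the read-out)), compound 3 gives 67.2%, the highest of the three figures, though compound 1 `Cc1ccc(-c2nc(CNc3ccc(C(=O)NO)cc3)n(-c3ccccc3)n2)cc1` with 62.2% lies within the usual scatter of it; compound 2 `O=C(NO)c1ccc(NCc2nc(-c3cccc4cnccc34)nn2-c2ccccc2)cc1` gives 40.2%. Compound 4 `O=C(NO)c1ccc(NCc2nc(-c3ccccc3)nn2-c2ccccc2)cc1` is the unmeasured member; the change from compound 3 is hydrogen in place of chloro on an aromatic carbon. The nearest guide is the step of a number 5 percentage points higher from compound 1 to compound 3 (within the scatter), which shows that swapping one small group for another on that ring left the number unchanged within scatter, whereas the step of a number 27 percentage points higher from compound 2 to compound 3 (beyond the scatter) involved a much larger group. Removing the chloro is therefore expected to shift this assay little, and compound 4 is estimated at 60%, between 45% and 75%, a step of a number 7.2 percentage points lower from compound 3 to compound 4 (within the scatter) that is expected to stay within the scatter.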

Compound 4, a percentage reported as inhibition, at one concentration (the size of the read-out at that concentration, not a potency): 72.6%
Estimate against measurement, compound 4: 12.6 percentage points below; low and high end bracket the measured number.
By their numbers in this assay, from the lowest: compound 2; then compounds 1, 3 and 4 (each within the scatter of the next, the first and the last beyond it).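

In this assay taking the chloro off gives a number 5.4 percentage points higher from compound 3 to compound 4 (within the scatter) and so the phenyl ring holds its number with no group at this carbon. Hydrogen in place of methyl gives a number 10.4 percentage points higher from compound 1 to compound 4 (beyond the scatter) and so a small step here can just pass the scatter, while phenyl in place of isoquinolin-5-yl gives a number 32.4 percentage points higher from compound 2 to compound 4 (beyond the scatter) as the widest gap in the set. Nothing available explains these differences. From the compounds shown here alone, whether an amine, a methoxy group or a carboxylic acid at this carbon would raise or lower the number stays open. Readings at one concentration also leave the compounds' potencies open.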